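This account rests on a few compounds, and the source may have more. Where it says the series, first, only, none or still open, it means among the compounds named here.

Compound 1 `CO/N=c1\[nH]cnc2c1[n+](C/C=C(\C)CC/C=C(/C)CCC=C(C)C)cn2C`: 736 nM
Compound 2 `CO/N=c1\[nH]cnc2c1[n+](C/C=C(\C)CC/C=C(\C)CC/C=C(\C)CCC=C(C)C)cn2C(c1ccccc1)c1ccccc1`: 2600 nM
Compound 3 `CO/N=c1\[nH]cnc2ncn(C/C=C(\C)CC/C=C(\C)CC/C=C(\C)CCC=C(C)C)c12`: 3000 nM

All three were tested in a functional assay on cells (Homo sapiens) for cytotoxicity; a lower number here means a stronger inhibitor, a higher number a weaker inhibitor. Compound 3 stands at the highest of the three numbers; compound 2 lies within the scatter of it, while compound 1 sits beyond the scatter at the lower end. Compound 4 `CC(C)=CCC/C(C)=C/CC/C(C)=C/CC/C(C)=C/Cn1cnc2nc[nH]/c(=N\OCc3ccccc3)c21` has not yet been measured in this assay. It differs from compound 3 by phenyl in place of hydrogen on a saturated chain carbon bound to an oxygen. For the measured compounds named here, no measured pair shows this change, so the size of the step is unknown from the data. The account expects no step beyond the scatter, in no clear direction. Compound 4 is therefore estimated to give 2500 nM, with a range from 900 nM to 7000 nM. That estimate means an expected 1.2-fold lower number from compound 3 to compound 4 (0.08 log units; within the scatter).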

Compound 4, half-maximal inhibitory concentration: 10900 nM
Beside the measured number, compound 4's estimate is 4.4-fold (0.64 log units) below it, and the stated range ends below it.
By their numbers in this assay, from the lowest: compound 1; then compounds 2 and 3 (each within the scatter of the next); then compound 4.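

In this assay, methoxy to benzyloxy gives a 3.6-fold higher number from compound 3 to compound 4 (0.56 log units; beyond the scatter), the first measured sign that this position responds to phenyl in place of hydrogen on a saturated chain carbon bound to an oxygen. Here the benzyloxy compound is the weaker inhibitor, although this rests on a single pair. No measured evidence accounts for the step. The compounds shown leave open how a longer chain between the oxygen and the phenyl would read, and whether an amine or a carboxylic acid on that phenyl would change the result.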